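The source may report more compounds than this note shows. Statements on the series, on what has been measured and on what is new or still open speak of the compounds shown alone.

In a functional assay on A549 cells (Homo sapiens) for inhibition, read by sulforhodamine B assay, with a stated time of 72 h (a lower number here means a stronger inhibitor, a higher number a weaker inhibitor), compound 1 (`Nc1sc(-c2ccc(Cl)cc2)c(-c2ccc(Cl)cc2)c1C(=O)NC1CCC1`) gives 12500 nM and compound 2 (`Nc1sc(-c2ccc(Cl)cc2)c(-c2ccc(Cl)cc2)c1C(=O)N1CCOCC1`) gives 1870 nM as the lower of the two numbers. Compound 3 (`CN1CCN(C(=O)c2c(N)sc(-c3ccc(Cl)cc3)c2-c2ccc(Cl)cc2)CC1`) keeps the core of compound 2 and changes only the group on the carbonyl carbon: 4-methylpiperazin-1-yl in place of morpholin-4-yl (4-methylpiperazin-1-yl in place of morpholin-4-yl on a carbonyl carbon), each a six-membered non-aromatic ring with 2 hetero atoms.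

Among the compounds with values here, the one measured step at this place is modest, a 6.7-fold lower number from compound 1 to compound 2 (0.83 log units; beyond the scatter) on going to morpholin-4-yl in place of cyclobutylamino. Within the data shown here, it shows that the number in this assay moves with the group on this carbonyl carbon, but no measured pair exchanges one of these two rings for the other, so the direction remains uncertain. Among the measured compounds shown here, the two rings resemble each other more than cyclobutylamino and morpholin-4-yl do, so a step smaller than the one reaching compound 2 at 1870 nM is expected, leaning slightly toward a higher number and probably inside the scatter. The estimated step is a 1.3-fold higher number from compound 2 to compound 3 (0.13 log units; within the scatter) as a working figure. The estimate for compound 3 is 2500 nM within an expected range of 900 nM to 7500 nM for repeat measurements.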

Compound 3, half-maximal inhibitory concentration: 590 nM
The estimate for compound 3 lay 4.2-fold (0.63 log units) above the measured number; the measured number lies below the stated range.
By their numbers in this assay, from the lowest: compound 3; then compound 2; then compound 1.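

Exchanging one six-membered non-aromatic ring with 2 hetero atoms for another is not a silent change on this carbonyl carbon: in this assay 4-methylpiperazin-1-yl in place of morpholin-4-yl gives a 3.2-fold lower number from compound 2 to compound 3 (0.50 log units; beyond the scatter) and so moves the number beyond the scatter. Against the open cyclobutylamino group the same ring gives a 21-fold lower number from compound 1 to compound 3 (1.33 log units; beyond the scatter) as the widest span in the set, and compound 3 is the strongest inhibitor of the three, with its steps to both others printed as beyond the scatter. No supporting measurement bears on why the number changes with these groups, so the order remains an observation only.

The step from morpholin-4-yl to 4-methylpiperazin-1-yl changes the ring oxygen to nitrogen and adds a methyl group in one move, so the compounds shown do not separate the two; the plain piperazin-1-yl group or 4-ethylpiperazin-1-yl on the same carbonyl carbon would divide that step. As far as these compounds go, whether the same order of the three groups holds on any other core also remains open, as all three compounds share one core.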